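Replacing Iodo with Bromo in Compound 3

This account rests on a few compounds, and the source may have more. Where it says the series, first, only, none or still open, it means among the compounds named here.

Among the measured compounds shown here, in an ADME assay on L6 cells (Rattus norvegicus) for cytotoxicity, read by resazurin assay, with a stated time of 72 h (on this read-out higher numbers stand for weaker inhibition and lower numbers for stronger inhibition), compound 2 `CC(=O)OC[C@H]1O[C@@H](N2C(=O)/C(=C3/C(=O)Nc4ccc(I)cc43)c3ccccc32)[C@H](OC(C)=O)[C@@H](OC(C)=O)[C@@H]1OC(C)=O` gives 11300 nM, the higher of the two numbers measured so far. For the measured compounds named here, the only other measured analogue, compound 1 `CC(=O)OC[C@H]1O[C@@H](N2C(=O)/C(=C3/C(=O)Nc4ccccc43)c3ccccc32)[C@H](OC(C)=O)[C@@H](OC(C)=O)[C@@H]1OC(C)=O`, gives 4530 nM. Compound 3 `CC(=O)OC[C@H]1O[C@@H](N2C(=O)/C(=C3/C(=O)Nc4ccc(Br)cc43)c3ccccc32)[C@H](OC(C)=O)[C@@H](OC(C)=O)[C@@H]1OC(C)=O` differs from compound 2 by one substitution, bromo in place of iodo on an aromatic carbon. Going by the values given here, no measured step makes this exact exchange. The closest evidence is a 2.5-fold higher number from compound 1 to compound 2 (0.40 log units; beyond the scatter), a modest change beyond the scatter, produced by iodo in place of hydrogen on an aromatic carbon. That single step shows what iodo does relative to hydrogen in this series, but it cannot show where bromo will fall. A number between those of the two measured compounds is a reasonable expectation, which implies a small move towards lower numbers in this assay, probably not beyond the scatter. The expected change is a 1.4-fold lower number from compound 2 to compound 3 (0.15 log units; within the scatter). For compound 3, the estimated value is 8000 nM, with an expected range of 4000 nM to 16000 nM.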

Compound 3, half-maximal inhibitory concentration: 7700 nM
Beside the measured number, compound 3's estimate is 1.0-fold (0.02 log units) above it, and the stated range covers the measured number.
By their numbers in this assay, from the lowest: compounds 1, 3 and 2 (each within the scatter of the next, the first and the last beyond it).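

In this assay bromo in place of iodo on this aromatic carbon gives a 1.5-fold lower number from compound 2 to compound 3 (0.17 log units; within the scatter) and bromo in place of hydrogen gives a 1.7-fold higher number from compound 1 to compound 3 (0.23 log units; within the scatter), so bromo cannot be told apart from either of the groups measured earlier at this place. The earlier compounds shown here showed one difference beyond the scatter, between hydrogen and iodo, and compound 3 adds that bromo, unlike iodo, does not stand clear of hydrogen here, leaving that pair as the only one of the three separated on this read-out. Nothing shown gives a reason for these differences or for their size.

On these data alone, it remains open whether chloro or fluoro on this carbon would also fall within the scatter of hydrogen, and whether an amine, a carboxylic acid or a methoxy group would move the number beyond it in either direction. Also open, as far as these compounds go, is whether iodo and bromo would give the same picture on another carbon of this ring, as all three compounds differ at this one place only.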